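The source may report more compounds than this note shows. Statements on the series, on what has been measured and on what is new or still open speak of the compounds shown alone.

Two compounds have been measured so far:
Compound 1, `N#Cc1c2n(c(=O)n(-c3ccccc3)c1=N)CCCCC2N1CCCC1`, giving 83.4% in a functional assay on the whole organism (strain albino) for inhibition, with Rattus norvegicus as the target, read by paw edema, with stated times of 1 h and 3 h, at a dose of 18 mmol/kg by the intraperitoneal route; on this read-out lower numbers stand for a weaker effect and higher numbers for a stronger effect at the one dose given.
Compound 2, `CCOC(=O)C(=O)NC1=C(C#N)C2C(N3CCCC3)CCCCN2C(=O)N1c1ccccc1`, giving 81.6% in this assay.

Compound 2 stands at the lower of the two numbers, but compound 1 is only slightly higher, and that gap lies within the usual scatter of the measurement, so the two compounds cannot be told apart on this read-out. The next compound, compound 3, `COC(=O)C(=O)NC1=C(C#N)C2C(N3CCCC3)CCCCN2C(=O)N1c1ccccc1`, has not been measured yet. It differs from compound 2 in a single spot: hydrogen in place of methyl on a saturated chain carbon bound to an oxygen next to a carbonyl group. A methyl leaves and a hydrogen enters, on a saturated chain carbon bound to an oxygen next to a carbonyl group; read one bond further out, an ethoxycarbonyl becomes a methoxycarbonyl. For the measured compounds named here, no pair of measured compounds differing in just one place exists here, so there is no measured step to lean on. A change this small is expected to leave the read-out roughly where it is: a number 1.6 percentage points lower from compound 2 to compound 3 (within the scatter) is expected to stay within the scatter, in no particular direction. Compound 3 is therefore estimated at 80%, between 68% and 90%.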

Compound 3, a percentage reported as inhibition, in the whole organism at one dose (the size of the read-out at that dose, not a potency): 86.2%
The estimate for compound 3 lay 6.2 percentage points below the measured number; the measured number falls inside the stated range.
By their numbers in this assay, from the lowest: compounds 2, 1 and 3 (each within the scatter of the next).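

In this assay, replacing the ethoxycarbonyl with a methoxycarbonyl gives a number 4.6 percentage points higher from compound 2 to compound 3 (within the scatter). For the compounds shown here, this is the first measured change at this position, and it shows that removing a methyl from the saturated chain carbon bound to an oxygen next to a carbonyl group does not separate the two compounds on this read-out: with only this pair in hand, the ethyl and methyl versions count as equal. Nothing available accounts for the small difference between them, so it offers no explanation of how this part of the molecule relates to the effect on paw edema.

What the pair leaves open is how much change this position can take, for instance with a longer chain such as butyl, or with a carboxylic acid or an amide in place of the ester. Going by these compounds, because the read-out gives the size of the effect at one dose rather than a potency, it also remains open whether compound 2 and compound 3 would still look alike at lower doses.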